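Selenocyanate aryl carbamates: benzyl analogue expected near the others

The source may report more compounds than this note shows. Statements on the series, on what has been measured and on what is new or still open speak of the compounds shown alone.

Measured so far in a functional assay on PC-3 cells (Homo sapiens) for cytotoxicity, read by MTT assay, with a stated time of 72 h; on this read-out lower numbers stand for stronger inhibition of growth and higher numbers for weaker inhibition of growth:
- compound 1 `N#C[Se]c1ccc(NC(=O)OCc2ccc([N+](=O)[O-])cc2)cc1`: 36500 nM
- compound 2 `N#C[Se]c1ccc(NC(=O)Oc2ccc(F)cc2)cc1`: 40400 nM
- compound 3 `C=CCOC(=O)Nc1ccc([Se]C#N)cc1`: 44700 nM

Compound 3 gives the highest of the three numbers, but its gap to compound 2 and its gap to compound 1 both lie within the scatter of repeated measurements, so the three compounds cannot be placed in any order on these data.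

Compound 4 `N#C[Se]c1ccc(NC(=O)OCc2ccccc2)cc1` has not yet been measured in this assay. It differs from compound 3 as follows: phenyl in place of vinyl on a saturated chain carbon bound to an oxygen next to a carbonyl group. The phenyl that enters sits on a saturated chain carbon bound to an oxygen next to a carbonyl group.

Since the three measured compounds do not separate from one another, the step from compound 3 to compound 4 is expected to stay within the scatter, with no direction that can be claimed. Compound 1 carries a related carbamate and gives 36500 nM, which supports a number in the same range. For compound 4 the estimated step is a 1.2-fold lower number from compound 3 to compound 4 (0.07 log units; within the scatter). Compound 4 is therefore expected to give about 38000 nM, with a range from 18000 nM to 80000 nM.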

Compound 4, concentration for total growth inhibition: 27800 nM
Compound 4: middle estimate off by 1.4-fold (0.14 log units), on the high side, within the range that was stated.
By their numbers in this assay, from the lowest: compounds 4, 1, 2 and 3 (each within the scatter of the next).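

In this assay the phenyl in place of vinyl on a saturated chain carbon bound to an oxygen next to a carbonyl group gives a 1.6-fold lower number from compound 3 to compound 4 (0.21 log units; within the scatter) and so leaves the number within the scatter, which shows that this position accepts a six-membered aromatic ring of carbon only as well as a vinyl without a readable change. Hydrogen in place of nitro on an aromatic carbon gives a 1.3-fold lower number from compound 1 to compound 4 (0.12 log units; within the scatter) and likewise cannot be read as a change, so the nitro on that phenyl is not needed to keep the number in this range. No supporting measurement bears on either step.

Still open, as far as these compounds go, is whether an amine or a carboxylic acid on that phenyl would move the number beyond the scatter. Also open, from the compounds shown here alone, is what a thiocyanate in place of the selenocyanate would do.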